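From furan side chain to formyl on the shared core

The source may hold more compounds than are shown below. What is called first, only, known or untested is meant among the compounds shown, and "the series" means these compounds.

Values in a functional assay on A-375 cells (Homo sapiens) for cytotoxicity, with a stated time of 24 h; on this read-out lower numbers stand for stronger inhibition and higher numbers for weaker inhibition:
Compound 1 `COC1CCC2C3C=C(/C=C/[C@H]4C(C)=CC(=O)[C@H]5C(C)(C)CCC[C@]45C)C(O3)C2O1`: 30.2 ug/mL; 31.1 ug/mL (2 entries)
Compound 2 `CC1=CC(=O)[C@H]2C(C)(C)CCC[C@]2(C)[C@H]1CCc1ccoc1`: 60 ug/mL
Compound 3 `CC1=CC(=O)[C@H]2C(C)(C)CCC[C@]2(C)[C@H]1C=O`: not yet measured

In this assay compound 2 stands at 60 ug/mL. Among the compounds with values here, this is the only number it has there, and one further entry for compound 2 gave no single number. The repeat entries for compound 1 agree closely, (the several entries of compound 1 in this assay, 30.2 ug/mL; 31.1 ug/mL (2 entries)), and its value lies within the usual scatter of that of compound 2, so the two cannot be ranked.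

Compound 3 keeps the core of compound 2 and changes one group: formyl in place of 2-(furan-3-yl)ethyl on a saturated ring carbon. Within the data shown here, no measured pair shows what such a change does, so the expectation is a loose one. It rests on compound 2 at 60 ug/mL as the closest anchor, and no step beyond the scatter is expected in this assay. The estimated step is a 1.2-fold lower number from compound 2 to compound 3 (0.08 log units; within the scatter). For compound 3 the expected value is 50 ug/mL, with an estimated range of 20 ug/mL to 120 ug/mL.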

Compound 3, half-maximal inhibitory concentration: 35.1 ug/mL
Compound 3: middle estimate off by 1.4-fold (0.15 log units), on the high side; low and high end bracket the measured number.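

Within the data shown here, this is the first step measured at this position: in this assay, replacing 2-(furan-3-yl)ethyl with formyl on the saturated ring carbon gives a 1.7-fold lower number from compound 2 to compound 3 (0.23 log units; within the scatter). Although the step removes the five-membered aromatic ring and shortens the substituent from a side chain to a single formyl group, the change stays within the usual scatter, so compound 2 and compound 3 cannot be ranked, and the furan ring is shown not to be needed for a reading in this range on these cells. The only repeat readings shown, which belong to a different compound, lie close together, but a single entry for compound 3 and a single number for compound 2 cannot turn this step into a real difference: the several entries of compound 1 in this assay, 30.2 ug/mL; 31.1 ug/mL (2 entries)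

The compounds shown leave open whether any group on this saturated ring carbon can move the number beyond the scatter, for example a carboxylic acid, an amine or a longer chain ending in a phenyl ring. They also leave open whether the same tolerance of the change would hold on cells other than those of this single cytotoxicity read-out.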